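This account rests on a few compounds, and the source may have more. Where it says the series, first, only, none or still open, it means among the compounds named here.

Measured compounds, cytotoxicity on the shared core:

compound 1 `CCCOCNc1n[n+]([O-])c2cc(OC)ccc2[n+]1[O-]` gives 1070 nM
compound 2 `COCNc1n[n+]([O-])c2ccccc2[n+]1[O-]` gives 2480 nM
compound 3 `[O-][n+]1nc(NCOCc2ccc(Cl)cc2)[n+]([O-])c2ccccc21` gives 810 nM

In a functional assay on SMMC-7721 cells (Homo sapiens) for cytotoxicity, read by MTT assay, with a stated time of 72 h (on this read-out lower numbers stand for stronger inhibition and higher numbers for weaker inhibition), compound 1 stands second highest of the three numbers; its nearest neighbour is compound 3, a gap within the scatter, while the gap to compound 2 lies beyond the scatter. Among the measured compounds shown here, the only single-place step among the measured compounds is a 3.1-fold lower number from compound 2 to compound 3 (0.49 log units; beyond the scatter), a change of a different kind from the one considered here.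

Compound 4 `CCCCCOCNc1n[n+]([O-])c2cc(OC)ccc2[n+]1[O-]` differs from compound 1 by ethyl in place of hydrogen on a saturated chain carbon, three bonds along the chain from an oxygen on a saturated carbon. For the measured compounds named here, no measured step extends the chain in this way; the step from compound 2 to compound 3 shows only that adding bulk on that chain can lower the number modestly. For compound 4 a step in this assay of about a 1.3-fold lower number from compound 1 to compound 4 (0.13 log units; within the scatter) is therefore expected, at most a small lowering, which may well sit within the scatter. The estimate for compound 4 is 800 nM, with a range from 400 nM to 1800 nM.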

Compound 4, half-maximal inhibitory concentration: 550 nM
Compound 4: middle estimate off by 1.5-fold (0.16 log units), on the high side, and the stated range covers the measured number.
By their numbers in this assay, from the lowest: compounds 4, 3 and 1 (each within the scatter of the next); then compound 2.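

In this assay, among the compounds shown here, the first direct reading of this chain extension is a 1.9-fold lower number from compound 1 to compound 4 (0.29 log units; within the scatter), so ethyl in place of hydrogen at this place, three bonds along the chain from an oxygen on a saturated carbon, leaves the number within the scatter. The earlier step at the chain covered only 4-chlorophenyl on a different carbon, whereas this one shows that the chain on the core of compound 1 accepts an extension with no ring and no step beyond the scatter. Nothing available explains the size of this step.

One step cannot show whether a longer chain would move the number beyond the scatter, or whether an amine or a carboxylic acid at the chain end would do so. As far as these compounds go, the same ethyl change on the core of compound 2 also remains open.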